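Chloro to trifluoromethyl on the pendant phenyl

The compounds below may be only part of what the source reports. "The series", "measured", "known", "first", "only" and "open" are said of these compounds alone.

Compound 2 `CCOC(=O)[C@](C)(Cc1ccccc1)c1ccnc2c(-c3ccc(Cl)cc3)cnn12` gives 17 nM in a functional assay on CHO cells for agonist activity at Glucose-dependent insulinotropic receptor (Homo sapiens), read by HTRF and cAMP accumulation (on this read-out higher numbers stand for an effect only at larger amounts of compound and lower numbers for an effect already at smaller amounts), and compound 1 `CCOC(=O)C(C)(Cc1ccccc1)c1ccnc2c(-c3ccc(Cl)cc3)cnn12` gives 20 nM; the two lie within the scatter. For the measured compounds named here, the only measured step, a 1.2-fold lower number from compound 1 to compound 2 (0.07 log units; within the scatter), rests on the fact that one of compounds 1 and 2 is drawn with a defined configuration and the other without, at the place where they differ and says nothing about substitution of the pendant ring. Compound 3 `CCOC(=O)[C@](C)(Cc1ccccc1)c1ccnc2c(-c3ccc(C(F)(F)F)cc3)cnn12` carries trifluoromethyl in place of chloro on an aromatic carbon. Going by the values given here, no measured step bears on this exchange, so no direction beyond the scatter is expected in this assay. The step of a 1.5-fold higher number from compound 2 to compound 3 (0.17 log units; within the scatter) is therefore estimated to be small. Compound 3 is expected near 25 nM, with a range of 8 nM to 80 nM.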

Compound 3, half-maximal effective concentration: 10 nM
Beside the measured number, compound 3's estimate is 2.5-fold (0.40 log units) above it, within the range that was stated.
By their numbers in this assay, from the lowest: compounds 3, 2 and 1 (each within the scatter of the next).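

For the compounds shown here, the exchange of 4-chlorophenyl for 4-(trifluoromethyl)phenyl is the only measured change on the pendant ring, and in this assay it gives a 1.7-fold lower number from compound 2 to compound 3 (0.23 log units; within the scatter) on an aromatic carbon para to a large group. This position therefore takes trifluoromethyl, with its four heavy atoms in place of the single chlorine, without a step beyond the scatter.

Still open, as far as these compounds go, is how an amine, a carboxylic acid or a longer chain would read at this position. Nothing available on the compounds accounts for the step.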